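Pyridin-4-yl in place of furan-2-yl

This account rests on a few compounds, and the source may have more. Where it says the series, first, only, none or still open, it means among the compounds named here.

In a functional assay on HeLa cells (Homo sapiens) for cytotoxicity, read by ELISA, with a stated time of 2 days (a lower number here means a stronger inhibitor, a higher number a weaker inhibitor), compound 1 `Oc1cccc(-c2cc(-c3ccccc3)cc(-c3cccs3)n2)c1` gives 17000 nM, compound 2 `Oc1cccc(-c2cc(-c3ccccc3)cc(-c3ccsc3)n2)c1` gives 13800 nM and compound 3 `Oc1cccc(-c2cc(-c3ccccc3)cc(-c3ccco3)n2)c1` gives 9430 nM. Compound 3 stands within the scatter of the other two measured compounds. The measured steps are a 1.2-fold lower number from compound 1 to compound 2 (0.09 log units; within the scatter), a 1.8-fold lower number from compound 1 to compound 3 (0.26 log units; within the scatter) and a 1.5-fold lower number from compound 2 to compound 3 (0.17 log units; within the scatter). Compound 4 `Oc1cccc(-c2cc(-c3ccccc3)cc(-c3ccncc3)n2)c1` carries pyridin-4-yl in place of furan-2-yl on an aromatic carbon. The measured steps exchange only five-membered aromatic rings, and none tests a six-membered aromatic ring at this place, so they bear on the change only indirectly. No shift beyond the scatter is expected in this assay, and the expected step is a 1.3-fold higher number from compound 3 to compound 4 (0.10 log units; within the scatter). For compound 4 the estimated value is 12000 nM, with an expected range from 5000 nM to 30000 nM.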

Compound 4, half-maximal inhibitory concentration: 28100 nM
Compound 4: middle estimate off by 2.3-fold (0.37 log units), on the low side; the measured number falls inside the stated range.
By their numbers in this assay, from the lowest: compounds 3, 2, 1 and 4 (each within the scatter of the next, the first and the last beyond it).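

In this assay pyridin-4-yl, the one six-membered aromatic ring at this place, gives a step beyond the scatter against two of the five-membered rings, with a 3.0-fold higher number from compound 3 to compound 4 (0.47 log units; beyond the scatter) and a 2.0-fold higher number from compound 2 to compound 4 (0.31 log units; beyond the scatter) while a 1.7-fold higher number from compound 1 to compound 4 (0.22 log units; within the scatter) stays within it. The position therefore responds modestly to this exchange, which the steps among the five-membered rings did not show, yet thiophen-2-yl goes against any clean split by ring size. No measurement on hand explains the step.

Open, going by these compounds, is how pyridin-3-yl or plain phenyl would read at this place. Also open, on these data alone, is whether an amine on the pyridine ring would move the number.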